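The source may report more compounds than this note shows. Statements on the series, on what has been measured and on what is new or still open speak of the compounds shown alone.

Measured so far in an ADME assay on cells (Lymphocyte, Homo sapiens) for cytotoxicity, read by MTT assay, with a stated time of 48 h; a lower number here means a stronger inhibitor, a higher number a weaker inhibitor:
compound 1 `COC(=O)/C(=C\c1ccc(OC(=O)c2ccc(OC)c(OC)c2)cc1)Sc1ccnc2cc(Cl)ccc12` gives 51100 nM
compound 2 `COC(=O)/C(=C\c1ccc(OC(=O)c2cc(OC)cc(OC)c2OC)cc1)Sc1ccnc2cc(Cl)ccc12` gives 74000 nM

For the measured compounds named here, compound 2, at 74000 nM, lies within the scatter of compound 1, the only other compound measured. Compound 3 `COC(=O)/C(=C\c1ccc(OC(=O)c2cc(OC)c(OC)cc2OC)cc1)Sc1ccnc2cc(Cl)ccc12` has the same atoms as compound 2, joined differently: it carries 2,4,5-trimethoxyphenyl in place of 2,3,5-trimethoxyphenyl on a carbonyl carbon and is otherwise unchanged. Going by the values given here, the one measured step bearing on this, also a change of the group on that carbonyl carbon, is a 1.4-fold higher number from compound 1 to compound 2 (0.16 log units; within the scatter), so no step beyond the scatter is expected in this assay in either direction. The expected step is a 1.1-fold lower number from compound 2 to compound 3 (0.06 log units; within the scatter) and no larger. The estimate for compound 3 is 65000 nM, with an expected range from 35000 nM to 120000 nM in this measurement.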

Compound 3, half-maximal inhibitory concentration: 52500 nM
Compound 3: the middle estimate sits 1.2-fold (0.09 log units) above what was measured; measured number inside the range.
By their numbers in this assay, from the lowest: compounds 1, 3 and 2 (each within the scatter of the next).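

In this assay, 2,4,5-trimethoxyphenyl in place of 2,3,5-trimethoxyphenyl on a carbonyl carbon gives a 1.4-fold lower number from compound 2 to compound 3 (0.15 log units; within the scatter), so rearranging the same atoms within this group does not take the number beyond the scatter. Methoxy in place of hydrogen on an aromatic carbon gives a 1.0-fold higher number from compound 1 to compound 3 (0.01 log units; within the scatter), which shows that an added methoxy group, tested here directly for the first time, also leaves the number within the scatter. No measurement is available that would explain this result.

All three compounds carry methoxy-substituted phenyl on that carbonyl carbon, so they do not show whether any group at this position can move the number beyond the scatter. An amine or a carboxylic acid on that phenyl, or an unsubstituted phenyl, remains an open case.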